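The source may hold more compounds than are shown below. What is called first, only, known or untested is meant among the compounds shown, and "the series" means these compounds.

Measured compounds:
compound 1 `O=C(Nc1nc2ccccc2s1)c1cn(-c2ccccc2)nc1-c1ccc(F)cc1` — 7130 nM
compound 2 `COc1ccc2nc(NC(=O)c3cn(-c4ccccc4)nc3-c3ccc(F)cc3)sc2c1` — 12800 nM

For the measured compounds named here, in a functional assay on PC-3 cells (Homo sapiens) for cytotoxicity, read by MTT assay, with a stated time of 72 h (a lower number here means a stronger inhibitor, a higher number a weaker inhibitor), compound 2 gives 12800 nM, the highest of the two numbers so far. The nearest is compound 1 with 7130 nM; the step of a 1.8-fold higher number from compound 1 to compound 2 (0.25 log units; within the scatter) lies within the scatter, so the two compounds cannot be set in order on this assay.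

Compound 3 `COc1ccc(-c2nn(-c3ccccc3)cc2C(=O)Nc2nc3ccc(OC)cc3s2)cc1` differs from compound 2 in one place: methoxy in place of fluoro on an aromatic carbon. Going by the values given here, no measured step covers this exchange. Among the compounds with values here, the only step in hand, a 1.8-fold higher number from compound 1 to compound 2 (0.25 log units; within the scatter), concerns a different position and was within the scatter, so it gives no direction for the change to compound 3. With nothing beyond the scatter seen in the series, the step expected for compound 3 is a 1.1-fold lower number from compound 2 to compound 3 (0.03 log units; within the scatter), no move beyond the usual scatter. The estimate for compound 3 is therefore 12000 nM, with a range from 4000 nM to 36000 nM.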

Compound 3, half-maximal inhibitory concentration: 13500 nM
Estimate against measurement, compound 3: 1.1-fold (0.05 log units) below, and the stated range covers the measured number.
By their numbers in this assay, from the lowest: compounds 1, 2 and 3 (each within the scatter of the next).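

Going from 4-fluorophenyl to 4-methoxyphenyl gives the first reading at this position: in this assay the exchange yields a 1.1-fold higher number from compound 2 to compound 3 (0.02 log units; within the scatter), so compound 2 and compound 3 cannot be set in order. The entering methoxy is counted with a hydrogen-bond acceptor and the leaving fluoro with none, yet this difference in the group produces no step beyond the scatter on this read-out. This is the second position in the series where an exchange stays within the scatter, and no measurement available here bears on the reason.

On these data alone, whether an amine or a carboxylic acid on this six-membered aromatic ring would give a step beyond the scatter remains open. So does whether a longer chain such as butoxy in place of methoxy would do so.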